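Azide in place of the carbamate on the pyrrolidine carbon

The source may report more compounds than this note shows. Statements on the series, on what has been measured and on what is new or still open speak of the compounds shown alone.

The study follows two compounds through an ADME assay on microsomes from liver (Homo sapiens) for metabolic stability, read by LC-MS, with NADPH named in the record, with a stated time of 60 min, tested at 1 uM, in the absence of a further agent (on this read-out higher numbers stand for a more stable compound and lower numbers for a less stable compound), and asks what a third would do. Compound 1, `COc1ccc(-c2c(C)sc3c(N4CC[C@@H](NC(C)=O)C4)nc(C)nc23)cc1OC`, is read only as a limit of the assay: in this assay compound 1 gives > 95%. Compound 2, `COc1ccc(-c2c(C)nc3c(N4CC[C@@H](NC(=O)OC5CCCCC5)C4)cc(C)nn23)cc1OC`, is likewise read only as a limit: in this assay compound 2 gives > 95%. On the numbers shown, compound 2 stands at the limit of the read-out, and both values sit there (the limit of > 95% in this assay, at which 2 of the 2 values shown sit), so no step between the two measured compounds can be told.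

Compound 3, `COc1ccc(-c2c(C)nc3c(N4CC[C@@H](N=[N+]=[N-])C4)cc(C)nn23)cc1OC`, has not yet been measured in this assay. It differs from compound 2 in one place (azido in place of (cyclohexyloxycarbonyl)amino on a saturated ring carbon). Among the measured compounds shown here, because compound 2 gives > 95% and no step within the measured pair points in any direction, the expected step is small, downward at most, and possibly none beyond the scatter. The estimate for compound 3 in this assay is 90%, with a range from 75% to 98%, which means an expected step of a number at least 5 percentage points lower from compound 2 to compound 3 (that floor lies within the scatter).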

Compound 3, percent of the compound remaining: > 95%
Compound 3: only a limit was reported (the forecaster's own chance of this, stated with the estimate: 50%); at least 5 percentage points between middle value and limit.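

In this assay compound 3 gives > 95%, which is a limit of the assay. Among the compounds shown here, no step from compound 2 to compound 3 can be read, because both stand at a limit: the limit of > 95% in this assay, at which 3 of the 3 values shown sit. The compounds shown leave open whether azido and (cyclohexyloxycarbonyl)amino on this saturated ring carbon differ at all in this assay.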